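This account rests on a few compounds, and the source may have more. Where it says the series, first, only, none or still open, it means among the compounds named here.

Measured so far in an ADME assay on Huh-7 cells (Homo sapiens) for cytotoxicity; a lower number here means that less compound is tolerated, a higher number that more compound is tolerated:
- Compound 1, `NC(=S)N1CCc2c(OCCCCCOc3ccc(Cl)cc3)cccc21`, gives only a limit, > 50000 nM.
- Compound 2, `O=C(NC(=S)N1CCc2c(OCCCCCOc3ccc(Cl)cc3)cccc21)c1ccc(Cl)cc1`, gives 21700 nM.
- Compound 3, `O=C(NC(=S)N1CCc2c(OCCCCCOc3ccc(Cl)cc3)cccc21)C1CCCCC1`, gives only a limit, > 50000 nM.

Compound 3 therefore stands at the limit of > 50000 nM in this assay, at which 2 of the 3 values shown sit, and no number, only a limit, is known for it. Compound 4 is `S=C(NC(=S)N1CCc2c(OCCCCCOc3ccc(Cl)cc3)cccc21)Oc1ccccc1`. Its difference from compound 3 is a group of 9 heavy atoms (7 carbon, 1 oxygen, 1 sulfur; one six-membered aromatic ring of carbon only) in place of a group of 8 heavy atoms (7 carbon, 1 oxygen; one six-membered non-aromatic ring of carbon only), on an amide-type nitrogen. Among the measured compounds shown here, two measured steps bear on this position. One, a step that the two limits leave unreadable from compound 1 to compound 3, has no readable size. For the measured compounds named here, the other, an at least 2.3-fold higher number from compound 2 to compound 3 (0.36 log units; beyond the scatter), shows that a non-aromatic cyclohexyl in place of an aromatic 4-chlorophenyl on the carbonyl carbon moved the number beyond the scatter; compound 2, the one carrying the aromatic ring, is also the only compound with a number rather than a limit. Compound 4 brings an aromatic ring back to the amide-type nitrogen, though within a different group. A modest downward step is therefore expected in this assay, an at least 1.4-fold lower number from compound 3 to compound 4 (0.15 log units; that floor lies within the scatter), with a fair chance that only a limit is reported again. Compound 4 is estimated at 35000 nM, in the range 15000 nM to 80000 nM.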

Compound 4, half-maximal cytotoxic concentration: > 50000 nM
Compound 4 was reported as a limit; the forecaster's own chance of this, stated with the estimate: 45%; middle value at least 1.4-fold (0.15 log units) away from the limit.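

In this assay, an aromatic ring on the amide-type nitrogen does not by itself go with a measurable number: the group in compound 4 carries a six-membered aromatic ring of carbon only, yet its result is a limit. Among the compounds shown here, exchanging one aromatic group for the other gives an at least 2.3-fold higher number from compound 2 to compound 4 (0.36 log units; beyond the scatter), so compound 2 remains the only compound with a number rather than a limit. The steps from compound 1 and from compound 3 to compound 4 cannot be read, and limits now make up most of the set: the limit of > 50000 nM in this assay, at which 3 of the 4 values shown sit.

As far as these compounds go, it remains open whether the chlorine of compound 2 or the oxygen and sulfur of compound 4 goes with that step, and a plain benzoyl group, with none of these atoms, could separate them. From the compounds shown here alone, how far compound 1, compound 3 and compound 4 lie from one another also remains unknown.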